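Swapping a Hydroxymethyl for a Carboxy Group

A few compounds are considered here, and "the series" means these few. Any claim that something is new, unique, unknown or untested is made for them only; others in the source may bear on it.

Of the compounds shown here, two have been measured so far. Compound 1, `C[C@H](CO)CCC[C@](C)(O)c1ccc(C(=O)O)cc1O`, gives 32000 nM in a functional assay on cells (Neutrophil, Homo sapiens) for inhibition, read by spectrophotometry, with a stated time of 5 min; a lower number here means a stronger inhibitor, a higher number a weaker inhibitor. Compound 2, `CC(C)CCC[C@](C)(O)c1ccc(CO)cc1O`, gives 5230 nM in this assay, the lowest of the two numbers, and its gap to compound 1 lies beyond the usual scatter. The two compounds differ in more than one place, so their values alone cannot be tied to a single change.

Compound 3, `CC(C)CCC[C@](C)(O)c1ccc(C(=O)O)cc1O`, is the unmeasured one. It differs from compound 2 in this way: carboxy in place of hydroxymethyl on an aromatic carbon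

Going by the values given here, no step between measured compounds isolates this change. Still, compound 1, which also carries a carboxy group, gives 32000 nM in this assay, and that points toward a weaker inhibitor. The expected step is a 3.4-fold higher number from compound 2 to compound 3 (0.54 log units; beyond the scatter), a move upward beyond the scatter. Compound 3 is therefore estimated at 18000 nM, with a likely range from 6000 nM to 55000 nM.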

Compound 3, half-maximal inhibitory concentration: 27800 nM
For compound 3 the middle estimate is 1.5-fold (0.19 log units) below the measured one, and the stated range covers the measured number.
By their numbers in this assay, from the lowest: compound 2; then compounds 3 and 1 (each within the scatter of the next).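

With carboxy in place of hydroxymethyl on an aromatic carbon as the only difference between the two compounds, this assay shows a 5.3-fold higher number from compound 2 to compound 3 (0.73 log units; beyond the scatter) as a step toward a weaker inhibitor, so this change alone moves the number beyond the scatter. The hydroxy group on the saturated chain shows no such effect among the carboxy compounds: hydrogen in its place gives a 1.2-fold lower number from compound 1 to compound 3 (0.06 log units; within the scatter) and so no readable change. No measured evidence here explains the step at the aromatic carbon.

From the compounds shown here alone, it remains open whether other groups on this aromatic carbon, such as an amide, a methyl ester or a nitrile, would stay close to compound 2 or fall near compound 3. Also open, going by these compounds, is whether the chain hydroxy group would matter alongside hydroxymethyl, and how a longer chain would behave.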